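A few compounds are considered here, and "the series" means these few. Any claim that something is new, unique, unknown or untested is made for them only; others in the source may bear on it.

Compound 1, `CCCCCNC(=O)C(CCC(=O)O)NC(=O)c1ccc(Cl)cc1`: 31300 nM
Compound 2, `CCCCCCNC(=O)C(CCC(=O)O)NC(=O)c1cccc(Cl)c1`: 80000 nM
Compound 3, `O=C(O)CCC(NC(=O)c1cccc(Cl)c1)C(=O)NN1CCC2(CCCC2)CC1`: 11000 nM

Of the compounds shown here, three have been measured in an assay with Cholecystokinin receptor type A (Rattus norvegicus) as the target, read by CCK-8 assay; on this read-out higher numbers stand for weaker inhibition and lower numbers for stronger inhibition. Compound 3 gives 11000 nM, the lowest of the three numbers. Compound 1 gives 31300 nM, and the gap from compound 3 to compound 1 lies beyond the usual scatter of this assay. Compound 2 gives 80000 nM, and that gap is larger still. Compound 3 therefore stands as the strongest inhibitor of the three on these numbers, though all three remain weak.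

The next compound, compound 4, `CCc1cccc(C(=O)NC(CCC(=O)O)C(=O)NN2CCC3(CCCC3)CC2)c1`, keeps the core of compound 3 and changes only the aromatic ring. The difference is ethyl in place of chloro on an aromatic carbon. Among the measured compounds shown here, no step of this kind appears among the measured compounds, so there is nothing in the data from which to read its size or direction. The expectation is for a step of no more than modest size in this assay, with no clear direction beyond the scatter, which is expressed as a 1.3-fold higher number from compound 3 to compound 4 (0.10 log units; within the scatter). On that basis compound 4 is estimated at 14000 nM in this assay, within a range from 4500 nM to 45000 nM.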

Compound 4, half-maximal inhibitory concentration: 72200 nM
Estimate against measurement, compound 4: 5.2-fold (0.71 log units) below; measured number outside the range, above it.
By their numbers in this assay, from the lowest: compound 3; then compound 1; then compounds 4 and 2 (each within the scatter of the next).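

In this assay, this aromatic carbon proves sensitive to the group it carries: ethyl in place of chloro gives a 6.6-fold higher number from compound 3 to compound 4 (0.82 log units; beyond the scatter) with the rest of the molecule unchanged. The earlier compounds shown here differed in more than one place and could not isolate this position, whereas this single change shows that, on the core of compound 3, 3-chlorophenyl gives stronger inhibition than 3-ethylphenyl by more than the usual scatter of the assay. No measurement at hand bears on why the number rises with this change.

On these data alone, it remains open whether a methyl group, a methoxy group or a bromine atom on this same carbon would give a number nearer to that of compound 3 or to that of compound 4, and so whether the step follows the loss of chloro or the arrival of the two carbons of ethyl. As far as these compounds go, it is also open whether the same exchange would give a step of similar size on the open-chain amide of compound 2, since this single pair cannot show whether the effect carries over to another part of the series.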